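This account rests on a few compounds, and the source may have more. Where it says the series, first, only, none or still open, it means among the compounds named here.

In a functional assay on T47D cells (Homo sapiens) for cytotoxicity, read by CCK-8 assay and cell counting, with stated times of 4 h and 2 days (on this read-out higher numbers stand for weaker inhibition and lower numbers for stronger inhibition), compound 1 (`Oc1cccc(-c2cc(-c3cccc(Cl)c3)cc(-c3ccco3)n2)c1`) gives 680 nM and stands level with its two closest relatives. Compound 2 (`Oc1cccc(-c2cc(-c3cccc(Cl)c3)cc(-c3cccs3)n2)c1`) gives 680 nM and compound 3 (`Oc1cccc(-c2cc(-c3cccc(Cl)c3)cc(-c3ccsc3)n2)c1`) gives 680 nM on the same read-out. These three share the 3-chlorophenyl group and differ only in carrying furan-2-yl, thiophen-2-yl or thiophen-3-yl. The exchanges among those groups show no change at the digits printed from compound 1 to compound 2 (within the scatter) as well as no change at the digits printed from compound 1 to compound 3 (within the scatter) and no change at the digits printed from compound 2 to compound 3 (within the scatter) in turn.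

Compound 4 (`Oc1cccc(-c2cc(-c3ccc(Cl)cc3)cc(-c3ccco3)n2)c1`) has not yet been measured. It keeps the furan-2-yl group of compound 1 and changes elsewhere, as 4-chlorophenyl in place of 3-chlorophenyl on an aromatic carbon shows: 4-chlorophenyl in place of 3-chlorophenyl on an aromatic carbon, opposite the ring nitrogen. For the measured compounds named here, no measured step touches this place, so the data offer no direct size for the move. The flat steps, such as no change at the digits printed from compound 1 to compound 2 (within the scatter) at the furan-2-yl place, are only indirect support. The expectation is therefore no shift beyond the scatter and no favoured direction, held with a wide margin. The estimated change is a 1.0-fold higher number from compound 1 to compound 4 (0.01 log units; within the scatter) on this evidence. Compound 4 is expected at about 700 nM (estimated range 250 nM to 2000 nM).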

Compound 4, half-maximal inhibitory concentration: 680 nM
For compound 4 the middle estimate is 1.0-fold (0.01 log units) above the measured one; the measured number falls inside the stated range.
By their numbers in this assay, from the lowest: compounds 1, 2, 3 and 4 (each within the scatter of the next).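

In this assay, the exchange of 3-chlorophenyl for 4-chlorophenyl, opposite the ring nitrogen, shows no change at the digits printed from compound 1 to compound 4 (within the scatter). For the compounds shown here, this gives the position a measured step of its own, whereas the earlier compounds varied only the furan-2-yl group, and it shows that with furan-2-yl in place, the two chlorophenyl groups cannot be told apart on this read-out. Nothing available explains why this exchange leaves the number in place.

Every compound shown carries a chlorophenyl group opposite the ring nitrogen, so it remains open whether an unsubstituted phenyl, a methoxyphenyl or an aminomethyl group there would give a step beyond the scatter. Also open, going by these compounds, are whether 4-chlorophenyl gives the same result alongside thiophen-2-yl or thiophen-3-yl, and whether the 3-hydroxyphenyl group shared by all four compounds could be replaced by a carboxylic acid or an amine without a shift.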